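A few compounds are considered here, and "the series" means these few. Any claim that something is new, unique, unknown or untested is made for them only; others in the source may bear on it.

Measured in a functional assay on KYSE-410 cells (Homo sapiens) for antiproliferative activity, read by MTT assay, with a stated time of 72 h; a higher number here means a weaker inhibitor, a lower number a stronger inhibitor:
- compound 1 `O=C(Nc1ccccn1)c1cc(=O)[nH]c2cc(Br)ccc12`: 9800 nM
- compound 2 `O=C(Nc1cc(F)ccc1F)c1cc(=O)[nH]c2cc(Br)ccc12`: > 20000 nM

Compound 2 stands only at a limit of the assay, > 20000 nM, and has no number.

Compound 3 `O=C(Nc1cccc(F)c1)c1cc(=O)[nH]c2cc(Br)ccc12` departs from compound 2 by hydrogen in place of fluoro on an aromatic carbon, ortho to a large group and para to a fluoro group.

Among the measured compounds shown here, no measured step bears on this change. Compound 1 gives 9800 nM, so weak activity is expected to persist in this assay. A small gain is expected, estimated as an at least 1.2-fold lower number from compound 2 to compound 3 (0.09 log units; that floor lies within the scatter). For compound 3 the estimate is 16000 nM, with an expected range of 7000 nM to 30000 nM.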

Compound 3, half-maximal inhibitory concentration: 7300 nM
Compound 3: middle estimate off by 2.2-fold (0.34 log units), on the high side; measured number inside the range.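

In this assay, hydrogen in place of fluoro on the aromatic carbon ortho to a large group and para to a fluoro group gives an at least 2.7-fold lower number from compound 2 to compound 3 (0.43 log units; beyond the scatter), the first measured read on this position. Compound 2 stands at a limit and has no number, so this step is only a bound: the limit of > 20000 nM in this assay, at which 1 of the 3 values shown sits. With 3-fluorophenyl in place of pyridin-2-yl on the amide-type nitrogen, the series shows a 1.3-fold lower number from compound 1 to compound 3 (0.13 log units; within the scatter), so these two groups are not separated here.

Still open, on these data alone, is whether chloro, methoxy or an amine at this position would match hydrogen. As far as these compounds go, the part played by the remaining fluoro group also stays open.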